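Cyclohexyl to 3-ethylphenyl: an estimate of solubility

This account rests on a few compounds, and the source may have more. Where it says the series, first, only, none or still open, it means among the compounds named here.

Compound 1 `O=C(O)c1ccc(CCOc2c(F)ccc3nc(C(=O)NCc4ccccc4)[nH]c(=O)c23)cc1` gives 6.3 ug/mL as a measured number
Compound 2 `O=C(O)c1ccc(CCOc2c(F)ccc3nc(C(=O)NCC4CCCCC4)[nH]c(=O)c23)cc1` gives < 1.6 ug/mL as a limit

In a physicochemical assay for solubility, read by nephelometry, in phosphate buffer, measured as kinetic solubility, at pH 6.5 (on this read-out higher numbers stand for higher solubility and lower numbers for lower solubility), compound 2 stands only at a limit (< 1.6 ug/mL) and not at a number. Compound 3 `CCc1cccc(CNC(=O)c2nc3ccc(F)c(OCCc4ccc(C(=O)O)cc4)c3c(=O)[nH]2)c1` differs from compound 2 as follows: 3-ethylphenyl in place of cyclohexyl on a saturated chain carbon bound to an amide-type nitrogen with 3-ethylphenyl in place of cyclohexyl on a saturated chain carbon bound to an amide-type nitrogen. Among the measured compounds shown here, the only measured step bearing on this is an at least 3.9-fold lower number from compound 1 to compound 2 (0.59 log units; beyond the scatter) and it lies beyond the scatter. That step ran the opposite way, from phenyl to cyclohexyl. For the measured compounds named here, since compound 1 gives 6.3 ug/mL with its phenyl, a modest rise is expected in this assay for this change, although no measured step covers the ethyl. The expected step is an at least 2.1-fold higher number from compound 2 to compound 3 (0.33 log units; beyond the scatter) on this read-out. Compound 3 is estimated at 3.5 ug/mL with an expected range from 1.6 ug/mL to 8 ug/mL on this read-out.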

Compound 3, solubility: 12.5 ug/mL
The estimate for compound 3 lay 3.6-fold (0.55 log units) below the measured number, and the stated range ends below it.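

In this assay, putting 3-ethylphenyl in place of cyclohexyl on a saturated chain carbon bound to an amide-type nitrogen gave an at least 7.8-fold higher number from compound 2 to compound 3 (0.89 log units; beyond the scatter), so the gap first seen with phenyl also appears with a substituted aromatic ring. The ethyl itself could not be told apart from hydrogen on this read-out, with a 2.0-fold higher number from compound 1 to compound 3 (0.30 log units; within the scatter). The size of the step from cyclohexyl remains only a bound, since compound 2 stands at a limit and not at a number: the limit of < 1.6 ug/mL in this assay, at which 1 of the 3 values shown sits.

The compounds shown leave open how an aromatic ring bearing an amine or a methoxy group would read in this assay. They also leave open whether a saturated ring containing nitrogen, such as piperidine, would read like cyclohexyl, and whether a longer chain would change the picture.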